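Moving a nitro group on a triazole-linked phenyl ring

This account rests on a few compounds, and the source may have more. Where it says the series, first, only, none or still open, it means among the compounds named here.

Compound 1 `C#Cc1cccc(Nc2ncnc3ccccc23)c1` and compound 2 `O=[N+]([O-])c1ccccc1-n1cc(-c2cccc(Nc3ncnc4ccccc34)c2)nn1` share a common core and were both tested in a functional assay on KB cells (Homo sapiens) for cytotoxicity, read by MTT assay, with a stated time of 3 days; a higher number here means a weaker inhibitor, a lower number a stronger inhibitor. In this assay compound 1 gives 5460 nM, and compound 2 gives 5500 nM. The two numbers lie within the usual scatter of each other, so neither can be told apart from the other on this evidence; compound 2 simply sits alongside compound 1 on the two numbers shown.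

Compound 3 `O=[N+]([O-])c1cccc(-n2cc(-c3cccc(Nc4ncnc5ccccc45)c3)nn2)c1` is a rearrangement of compound 2 with the same atoms joined differently: 3-nitrophenyl in place of 2-nitrophenyl on an aromatic nitrogen. Among the measured compounds shown here, no measured pair in this set shows what shifting a nitro group from one ring position to another does in this assay, so there is no step from which to draw a direction. In its absence, the expectation is a step from compound 2 to compound 3 of a 1.1-fold lower number from compound 2 to compound 3 (0.04 log units; within the scatter), that is, nothing beyond the scatter in either direction. Compound 3 is therefore estimated at 5000 nM in this assay, with a range from 1500 nM to 16000 nM.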

Compound 3, half-maximal inhibitory concentration: 104000 nM
Compound 3: middle estimate off by 21-fold (1.32 log units), on the low side; measured number above the stated range.
By their numbers in this assay, from the lowest: compounds 1 and 2 (each within the scatter of the next); then compound 3.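

In this assay, among the compounds shown here, moving the nitro group so that 3-nitrophenyl replaces 2-nitrophenyl on an aromatic nitrogen of the five-membered aromatic ring with 3 nitrogen gives a 19-fold higher number from compound 2 to compound 3 (1.28 log units; beyond the scatter), a large step that shows this part of the molecule is sensitive to where the nitro group sits on its phenyl ring, something the earlier compounds could not reveal. The two groups have the same heavy atoms, the same six-membered aromatic ring and the same counts of hydrogen-bond donors and acceptors, so none of those counts separates them and the difference lies only in how the atoms are joined. Nothing at hand bears on why a shift within one ring changes the number this much.

The compounds shown leave open whether 4-nitrophenyl or plain phenyl on the same nitrogen would sit with compound 2 or with compound 3. They also leave open whether an amine or a carboxylic acid in place of the nitro group would depend on its ring position in the same way.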